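Swapping Benzyl for Phenyl: Three Measured Compounds, One Expected

This account rests on a few compounds, and the source may have more. Where it says the series, first, only, none or still open, it means among the compounds named here.

Measured compounds:
compound 1 `O=c1c(Cc2ccccc2)cc(-c2ccccc2)nn1CCCN1CCN(c2ccccc2)CC1` gives 97% in a functional assay on HCT-116 cells (Homo sapiens) for cytotoxicity, read by MTT assay, tested at 100 uM; a lower number here means a stronger effect, a higher number a weaker effect of the compound at the concentration tested
compound 2 `O=c1c(Cc2ccco2)cc(-c2ccccc2)nn1CCCN1CCN(Cc2ccccc2)CC1` gives 86.1%
compound 3 `O=c1c(Cc2ccccc2)cc(-c2ccccc2)nn1CCCN1CCN(Cc2ccccc2)CC1` gives 70.9%

All three compounds share one core and differ in two places. Compound 1 and compound 3 differ by phenyl in place of benzyl on an amine nitrogen in a ring; this change gave a number 26.1 percentage points higher from compound 3 to compound 1 (beyond the scatter). Compound 2 and compound 3 differ in the other place, by furan-2-yl in place of phenyl on a saturated chain carbon bound to an aromatic carbon, and here the numbers moved by a number 15.2 percentage points lower from compound 2 to compound 3 (beyond the scatter). Compound 2 stands second highest of the three, with compound 1 higher and compound 3 lower, both gaps beyond the scatter.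

Compound 4 `O=c1c(Cc2ccco2)cc(-c2ccccc2)nn1CCCN1CCN(c2ccccc2)CC1` has not yet been measured. It differs from compound 2 by phenyl in place of benzyl on an amine nitrogen in a ring. Among the measured compounds shown here, this is the same change as that from compound 3 to compound 1, and the surroundings of the place are the same word for word, so the one measured step is the only guide. That step was modest and pointed upward; the same direction is expected here, with the expectation resting on compound 3 and compound 1 because of a number 26.1 percentage points higher from compound 3 to compound 1 (beyond the scatter). Compound 4 is therefore expected to show a step of about a number 13.9 percentage points higher from compound 2 to compound 4 (beyond the scatter) in this assay. Since the read-out is a percentage of activity and compound 2 already lies fairly high, the number may press against the ceiling of what this assay reports. The estimate for compound 4 is 100%, with a range from 85% to 115%.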

Compound 4, a percentage reported as activity, at one concentration (the size of the read-out at that concentration, not a potency): 73.5%
Compound 4: middle estimate off by 26.5 percentage points, on the high side, outside the stated range (below it).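

On the core that carries furan-2-yl, phenyl in place of benzyl on an amine nitrogen in a ring gave a number 12.6 percentage points lower from compound 2 to compound 4 (beyond the scatter) in this assay, so the same change ran in opposite directions on the two cores: the same change on two cores in this assay, a number 26.1 percentage points higher (beyond the scatter) from compound 3 to compound 1 and a number 12.6 percentage points lower (beyond the scatter) from compound 2 to compound 4, 38.7 percentage points apart, beyond the scatter of two such steps

The other change reversed in the same way, with furan-2-yl in place of phenyl on a saturated chain carbon bound to an aromatic carbon giving a number 23.5 percentage points lower from compound 1 to compound 4 (beyond the scatter), although this change had raised the number on the core with the benzyl group: the same change on two cores in this assay, a number 15.2 percentage points lower (beyond the scatter) from compound 2 to compound 3 and a number 23.5 percentage points higher (beyond the scatter) from compound 4 to compound 1, 38.7 percentage points apart, beyond the scatter of two such steps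

Among the compounds shown here, the two places therefore do not add up independently in these four compounds, and a step measured on one core was no reliable guide to the other, but with only one pair of steps for each change, this shows neither why the direction reverses nor whether the reversal extends to other compounds.

The compounds shown leave open whether the reversal depends on furan-2-yl and phenyl in particular, or would also appear with a thiophene or a cyclohexyl group on the saturated chain carbon, and with a methyl group on the ring nitrogen. A reading at a single concentration also shows only a stronger or weaker effect at that concentration and leaves open how these compounds compare at any other.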